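One ring swap and the expected half-life of compound 3

The source may report more compounds than this note shows. Statements on the series, on what has been measured and on what is new or still open speak of the compounds shown alone.

In an ADME assay on microsomes from liver (Rattus norvegicus) for metabolic stability (on this read-out lower numbers stand for a shorter-lived compound and higher numbers for a longer-lived compound), compound 1 `COc1cc(OCc2cccc(-c3ccc(C#N)cn3)c2)c2cc(-c3cn4nc(OC)sc4n3)oc2c1` gives 0.833 h. Going by the values given here, the only other measured compound, compound 2 `COc1cc(OCc2csc(-c3ccc(S(C)(=O)=O)cc3)n2)c2cc(-c3cn4nc(OC)sc4n3)oc2c1`, gives 1.12 h. These two values lie within the usual scatter of repeated measurements, so neither compound can be ranked over the other.

Compound 3 `COc1cc(OCc2cccc(-c3cncnc3)c2)c2cc(-c3cn4nc(OC)sc4n3)oc2c1` has not been measured yet. It keeps the core of compound 1 but carries pyrimidin-5-yl in place of 5-cyanopyridin-2-yl, on an aromatic carbon of a six-membered aromatic ring of carbon only: pyrimidin-5-yl in place of 5-cyanopyridin-2-yl on an aromatic carbon.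

Among the compounds with values here, no two measured compounds differ in just one place, so the data offer no direct guide to this swap. The only hint is indirect: compound 2, at 1.12 h, differs from compound 1 in more than one place, yet the two stay within the scatter of each other. On that thin basis, no step beyond the scatter is expected in this assay. The estimated step is a 1.1-fold higher number from compound 1 to compound 3 (0.03 log units; within the scatter). For compound 3 the expected value is 0.9 h, with an estimated range of 0.45 h to 1.8 h.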

Compound 3, half-life: 0.117 h
The estimate for compound 3 lay 7.7-fold (0.89 log units) above the measured number, outside the stated range (below it).
By their numbers in this assay, from the lowest: compound 3; then compounds 1 and 2 (each within the scatter of the next).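

In this assay, going by these compounds alone, putting pyrimidin-5-yl in place of 5-cyanopyridin-2-yl gives a 7.1-fold lower number from compound 1 to compound 3 (0.85 log units; beyond the scatter) and this is the first comparison here in which only one place differs. It shows that this spot, on an aromatic carbon of a six-membered aromatic ring of carbon only, is not indifferent to what it carries: changing this one group moves the half-life beyond the scatter while the rest of the molecule stays the same. The two groups match in their hydrogen-bond acceptor count and in having no net charge, so those counts alone do not tell the outcome, and nothing available explains the shorter half-life.

Open, going by these compounds, is whether the lower number goes with the extra hetero atom in the ring or with the lost nitrile, as the two change together in this single step. Also open, on these data alone, is how a pyridin-3-yl group without a nitrile, or a pyrimidin-5-yl group carrying a nitrile or an amine, would behave at this place.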